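Series notes: solubility ahead of compound 4

The source may hold more compounds than are shown below. What is called first, only, known or untested is meant among the compounds shown, and "the series" means these compounds.

Three compounds of the shared core have been run in a physicochemical assay for solubility; a higher number here means a more soluble compound, a lower number a less soluble compound. Compound 1 `CNC(=O)c1cc(C(=O)NC2CCC2)cn(Cc2ccccn2)c1=O` gives >= 103 ug/mL, which is a limit of the assay. Compound 2 `CNC(=O)c1cc(C(=O)NC2CC2)cn(CC2CCCOC2)c1=O` gives >= 131 ug/mL, again a limit. Compound 3 `CNC(=O)c1cc(C(=O)NCCO)cn(Cc2ccccc2)c1=O` gives >= 140 ug/mL, also a limit. Among the measured compounds shown here, compound 2 therefore stands only at a limit, and the two other values shown are limits as well, so no step between measured compounds can be read off. Compound 4 `CNC(=O)c1cc(C(=O)NC2CC2)cn(Cc2cccc([C@@H](C)O)c2)c1=O` differs from compound 2 by 3-(1-hydroxyethyl)phenyl in place of oxan-3-yl on a saturated chain carbon bound to an aromatic nitrogen. For the measured compounds named here, no measured step covers such a change, so in this assay a step from compound 2 to compound 4 is expected to stay within the scatter, or at most to be a small loss. Compound 4 is estimated at 100 ug/mL, with a range from 40 ug/mL to 220 ug/mL, meaning a step of an at least 1.3-fold lower number from compound 2 to compound 4 (0.11 log units; that floor lies within the scatter).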

Compound 4, solubility: >= 131 ug/mL
Compound 4: a limit, no number; the forecaster's own chance of this, stated with the estimate: 45%; middle value at least 1.3-fold (0.11 log units) from the limit.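

Among the compounds shown here, compound 2 and compound 4 both stand as limits in this assay, so no step between them can be read. Still open, as far as these compounds go, is whether 3-(1-hydroxyethyl)phenyl in place of oxan-3-yl shifts the read-out at all, and in which direction.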